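The compounds below may be only part of what the source reports. "The series", "measured", "known", "first", "only" and "open" are said of these compounds alone.

Measured so far in an assay on isolated protein for inhibition of aldehyde dehydrogenase 1A1 (Homo sapiens), read by fluorescence; a lower number here means a stronger inhibitor, a higher number a weaker inhibitor:
compound 2, `Cc1cc(C=O)ccc1N1CCCC1`: 800 nM
compound 1, `CCCN(CCC)c1ccc(C=O)cc1Br`: 7080 nM

Among the measured compounds shown here, compound 2 holds the lowest of the two numbers; the only other number, that of compound 1, lies higher by a margin beyond the scatter. For the measured compounds named here, no step between measured compounds that differ in one place is available, so nothing measured anticipates the change at hand.

Compound 3, `COc1cc(C=O)ccc1N1CCCC1`, differs from compound 2 by methoxy in place of methyl on an aromatic carbon. Going by the values given here, with no comparable step to lean on, the expectation is a small step, likely not beyond the scatter, and if anything toward a slightly higher number. Compound 3 is estimated at 1200 nM in this assay, with a range from 400 nM to 4000 nM. That estimate means an expected step of a 1.5-fold higher number from compound 2 to compound 3 (0.18 log units; within the scatter), to be checked once the measurement is in hand.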

Compound 3, half-maximal inhibitory concentration: 880 nM
Compound 3: the middle estimate sits 1.4-fold (0.13 log units) above what was measured; the measured number falls inside the stated range.
By their numbers in this assay, from the lowest: compounds 2 and 3 (each within the scatter of the next); then compound 1.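

In this assay, among the compounds shown here, methoxy in place of methyl on this aromatic carbon, ortho to a group of 5 heavy atoms and meta to a formyl group, gives a 1.1-fold higher number from compound 2 to compound 3 (0.04 log units; within the scatter) and supplies the first one-place step. The position therefore takes the added oxygen and its hydrogen-bond acceptor with no difference that can be separated from the scatter. No accompanying measurement accounts for this step.

From the compounds shown here alone, only these two groups have been compared at this carbon, so it remains open whether a hydroxyl, an amine, a carboxylic acid or a longer alkoxy chain would read the same. Compound 1 differs from compound 2 and compound 3 in more than one place, so its higher number cannot be assigned to any single group.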